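The source may report more compounds than this note shows. Statements on the series, on what has been measured and on what is new or still open speak of the compounds shown alone.

For the measured compounds named here, in an ADME assay on microsomes from liver (Homo sapiens) for metabolic stability, read by LC-MS, with a stated time of 10 min, tested at 0.5 uM (on this read-out higher numbers stand for a more stable compound and lower numbers for a less stable compound), only two compounds have numbers so far. Compound 1 `c1cnc2c(c1)CCC[C@@H]2N(CCCN1CCNCC1)Cc1cc2ccccc2cn1` gives 66%. Compound 2 `c1cnc2c(c1)CN[C@H](CN(CCCN1CCNCC1)[C@H]1CCCc3cccnc31)C2` gives 100%, the higher of the two numbers and clear of the usual scatter. Going by the values given here, the only measured step is a number 34 percentage points higher from compound 1 to compound 2 (beyond the scatter). It is large, but it exchanges a whole group on a saturated chain carbon bound to an amine nitrogen, so it offers only a loose guide to what a change of configuration might do.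

The next compound is compound 3 `c1cnc2c(c1)CN[C@@H](CN(CCCN1CCNCC1)[C@H]1CCCc3cccnc31)C2`, and its relation to compound 2 is this: the two compounds have the same atoms and bonds and differ only in configuration as drawn: 1 of 2 stereo elements differ; a stereocentre at a saturated ring carbon is drawn S in compound 2 and R in compound 3. Among the compounds with values here, nothing leaves and nothing enters, and no measured pair yet isolates such a change. That leaves the size of the effect open. Compound 2, at 100%, leaves little room for a rise, so any real movement would more likely be downward. The expected result is a small drop that stays within the scatter, estimated as a number 9 percentage points lower from compound 2 to compound 3 (within the scatter). For compound 3 the estimated value is 91%, with an expected range from 72% to 100%.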

Compound 3, percent of the compound remaining: 79%
Estimate against measurement, compound 3: 12 percentage points above; the measured number falls inside the stated range.
By their numbers in this assay, from the lowest: compound 1; then compound 3; then compound 2.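

For the compounds shown here, this is the first measured step that isolates a change of configuration, and in this assay it shows a number 21 percentage points lower from compound 2 to compound 3 (beyond the scatter). The size of the change is therefore not negligible at this position, and for this pair it can be assigned to the stereocentre at a saturated ring carbon, drawn S in compound 2 and R in compound 3: the fact that compounds 2 and 3 differ only in the configuration as drawn. It also qualifies the earlier group exchange. The same exchange on a saturated chain carbon bound to an amine nitrogen gives a number 13 percentage points higher from compound 1 to compound 3 (beyond the scatter) with the R form, against a number 34 percentage points higher from compound 1 to compound 2 (beyond the scatter) with the S form, and the size of that gain depends on the configuration of the incoming group.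

The compounds shown leave open whether the S form keeps its edge when the second stereo element is inverted, since that element stays as drawn in compound 2 and compound 3. They also leave open whether configuration matters as much when a methyl group sits on the ring nitrogen of the incoming group, or when a longer chain replaces the chain that carries the piperazine.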